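The source may report more compounds than this note shows. Statements on the series, on what has been measured and on what is new or still open speak of the compounds shown alone.

Working notes on the sulfonamide series

The shared core carries an amide on one side and an arylsulfonamide on the other, and the three measured compounds vary both aryl groups. Compound 1 `O=C(NCc1ccc(CNS(=O)(=O)c2ccccc2Cl)cc1)c1cccnc1` gives 100 nM in an assay on MDA-MB-231 cells for displacement of a labelled ligand from C-X-C chemokine receptor type 4 (Homo sapiens), read by fluorescence and microscopy, with stated times of 10 min and 30 min (a higher number here means that more compound is needed for the effect, a lower number that less compound is needed), the highest number of the three measured; the nearest is compound 3 `Cc1ccccc1C(=O)NCc1ccc(CNS(=O)(=O)c2ccccc2C)cc1`, which gives 10 nM, and the furthest is compound 2 `Cc1ccccc1C(=O)NCc1ccc(CNS(=O)(=O)c2ccc(Cl)cc2)cc1`, which gives 1 nM. Compound 1 differs from both in more than one place, so those gaps cannot be pinned to a single change.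

Compound 4 `Cc1cccc(S(=O)(=O)NCc2ccc(CNC(=O)c3cccnc3)cc2)c1` is compound 1 with the change (3-methylphenyl in place of 2-chlorophenyl on a sulfonyl sulfur).

Among the compounds with values here, only one measured step touches the aryl on the sulfonyl sulfur: a 10-fold higher number from compound 2 to compound 3 (1.00 log units; beyond the scatter), where a methylphenyl replaces a chlorophenyl, as here, though the substituent positions are not the same. On that evidence the replacement of chlorine by methyl on this aryl has run toward a higher number, and the same direction is expected for compound 4, though with less confidence because the positions differ from the measured pair.

For compound 4 the estimated step is a 2.0-fold higher number from compound 1 to compound 4 (0.30 log units; within the scatter), giving an expected value of 200 nM with a range from 60 nM to 700 nM.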

Compound 4, effective concentration (reported as EC, without a stated level of effect): 10 nM
Beside the measured number, compound 4's estimate is 20-fold (1.30 log units) above it; measured number below the stated range.
By their numbers in this assay, from the lowest: compound 2; then compounds 3 and 4 (each within the scatter of the next); then compound 1.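

On the sulfonyl sulfur, 3-methylphenyl in place of 2-chlorophenyl gives a 10-fold lower number from compound 1 to compound 4 (1.00 log units; beyond the scatter) in this assay, so a methylphenyl at this place does not go with a higher number in every pair: the earlier step, a 10-fold higher number from compound 2 to compound 3 (1.00 log units; beyond the scatter), ran the other way for 2-methylphenyl in place of 4-chlorophenyl. The two steps differ both in the substituent positions on this aryl and in the aryl group on the amide side, so their opposite directions cannot be assigned to either difference alone. Nothing at hand gives a reason for the change in direction.

The compounds shown leave open how much of the step depends on the position of the substituent and how much on its identity, a question that 3-chlorophenyl and 2-methylphenyl on the sulfonyl sulfur of the core of compound 1 would address directly. Also open, on these data alone, is whether the 3-methylphenyl step carries over to the core of compound 2, and how a methoxy group or a carboxylic acid on this aryl would read in the same assay.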